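Benzyl swap on the ring nitrogen, judged against limits

The source may report more compounds than this note shows. Statements on the series, on what has been measured and on what is new or still open speak of the compounds shown alone.

Compound 1 `Cc1ccc2c(NCc3ccc(NC(=O)C4CCN(Cc5ccccc5)CC4)cc3)nc(N3CCC3)nc2c1` in a functional assay on SV5A8 cells (Homo sapiens) for cytotoxicity (a higher number here means a weaker inhibitor, a lower number a stronger inhibitor), reaches only the limit > 8500 nM.
Compound 2 `COc1ccc(CN2CCC(C(=O)Nc3ccc(CNc4nc(N(C)C)nc5cc(C)ccc45)cc3)CC2)cc1` in this assay reaches only the limit > 6180 nM.
Compound 3 `Cc1ccc2c(NCc3ccc(NC(=O)C4CCN(Cc5ccccc5)CC4)cc3)nc(N3CCC(N4CCCC4)CC3)nc2c1` in this assay reaches only the limit > 8090 nM.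

Compound 2 thus stands at a limit, and the two other values shown are limits as well (the limit of > 6180 nM in this assay, at which 1 of the 3 values shown sits, (the limit of > 8090 nM in this assay, at which 1 of the 3 values shown sits), (the limit of > 8500 nM in this assay, at which 1 of the 3 values shown sits)). Compound 4 `Cc1ccc2c(NCc3ccc(NC(=O)C4CCN(Cc5ccc(F)cc5Cl)CC4)cc3)nc(N(C)C)nc2c1` differs from compound 2 by 2-chloro-4-fluorophenyl in place of 4-methoxyphenyl on a saturated chain carbon bound to an amine nitrogen in a ring. Going by the values given here, the only measured step, a step that the two limits leave unreadable from compound 1 to compound 3, runs between two limits and gives no readable size, and it changes another part of the shared core. Among the compounds with values here, no measured step bears on the change in the benzyl group, so nothing shows a shift in this assay beyond the scatter in either direction. Compound 4 is therefore expected to stay near the limits, with a step that the limit leaves unreadable from compound 2 to compound 4 as the estimated step. Compound 4 is estimated at 10000 nM, within 3000 nM and 30000 nM.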

Compound 4, half-maximal inhibitory concentration: > 5910 nM
Compound 4: a limit, no number (the forecaster's own chance of this, stated with the estimate: 80%); the middle value does not contradict the limit.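

Compound 2 and compound 4 both stand only at limits in this assay, and the step between them cannot be read. The compounds shown leave open whether 2-chloro-4-fluorophenyl in place of 4-methoxyphenyl shifts the value at all.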